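Cycloheptyl-urea series: piperazine to pyrazole swap on the benzyl

The source may hold more compounds than are shown below. What is called first, only, known or untested is meant among the compounds shown, and "the series" means these compounds.

Values in an assay on microsomes from intestine for inhibition of acyl-CoA:cholesterol acyltransferase (Oryctolagus cuniculus); a lower number here means a stronger inhibitor, a higher number a weaker inhibitor:
compound 1, `Cc1cc(C)c(NC(=O)N(Cc2ccc(N3CCN(C)CC3)cc2)C2CCCCCC2)c(C)c1`, 57 nM
compound 2, `CSc1cc(C)nc(SC)c1NC(=O)N(Cc1ccccc1)Cc1cccc(-c2ccn(C)n2)c1`, 73 nM
compound 3, `Cc1cc(C)c(NC(=O)N(Cc2cccc(-n3cccc3)c2)C2CCCCCC2)c(C)c1`, 20 nM

Compound 1 gives the second highest of the three numbers. Its value and that of compound 2 lie within the scatter of each other, so nothing separates them. Compound 3 sits at a lower number than compound 1, beyond the scatter.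

Among the compounds with values here, no pair of measured compounds differs in a single place, so the move to compound 4 `Cc1cc(C)c(NC(=O)N(Cc2ccc(-c3ccnn3C)cc2)C2CCCCCC2)c(C)c1` rests on the structures alone. Compound 4 differs from compound 1 in one spot: 1-methyl-1H-pyrazol-5-yl in place of 4-methylpiperazin-1-yl on an aromatic carbon. The shared core is unchanged. Compound 3 shows that a different substituent on this core can reach a lower number than compound 1, but that is not a like-for-like comparison and sets no rule.

In this assay a small step is expected, if anything toward a lower number, and most likely within the scatter. Compound 4 is estimated at 40 nM, with a range from 12 nM to 130 nM. That estimate corresponds to an expected step of a 1.4-fold lower number from compound 1 to compound 4 (0.15 log units; within the scatter).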

Compound 4, half-maximal inhibitory concentration: 24 nM
Estimate against measurement, compound 4: 1.7-fold (0.22 log units) above; measured number inside the range.
By their numbers in this assay, from the lowest: compounds 3 and 4 (each within the scatter of the next); then compounds 1 and 2 (each within the scatter of the next).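

In this assay, 1-methyl-1H-pyrazol-5-yl in place of 4-methylpiperazin-1-yl on this aromatic carbon, para to a large group, gives a 2.4-fold lower number from compound 1 to compound 4 (0.38 log units; beyond the scatter) on an otherwise unchanged core. Within the data shown here, this is the first like-for-like reading at this position, and it shows that a five-membered aromatic ring can stand here in place of a six-membered non-aromatic ring without a loss in this assay. The two groups have the same counts of hydrogen-bond donors and acceptors, yet the step lies beyond the scatter, so those counts alone do not set the number, and no measurement on hand accounts for the step.

Still open, on these data alone, is whether the step follows from the aromatic ring itself or from the removal of the methylpiperazine. A phenyl ring, a morpholine or a carboxylic acid on this same carbon would help to separate the two readings.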